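Three Inactive Analogues and a Dichlorophenyl Variant

This account rests on a few compounds, and the source may have more. Where it says the series, first, only, none or still open, it means among the compounds named here.

The set rests on a shared core carrying a substituted phenyl on an aromatic nitrogen. Compound 1 `N#CC1=C(N)Oc2c(N)cc3nc4ccccc4nc3c2C12C(=O)N(Cc1cnnn1-c1ccc(Cl)cc1)c1ccccc12` bears a 4-chlorophenyl there. In a functional assay on HCT-116 cells (Homo sapiens) for antiproliferative activity, read by MTT assay, with a stated time of 48 h (a higher number here means a weaker inhibitor, a lower number a stronger inhibitor), compound 1 gives only a limit, > 50000 nM. Compound 2 `N#CC1=C(N)Oc2c(N)cc3nc4ccccc4nc3c2C12C(=O)N(Cc1cnnn1-c1ccccc1Cl)c1ccccc12` has a 2-chlorophenyl instead. In this assay compound 2 also gives only a limit, > 50000 nM. Compound 3 `COc1ccccc1-n1nncc1CN1C(=O)C2(C(C#N)=C(N)Oc3c(N)cc4nc5ccccc5nc4c32)c2ccccc21` carries a 2-methoxyphenyl. In this assay compound 3 likewise gives only a limit, > 50000 nM. Compound 3 therefore stands with the other two, and its standing cannot be ranked, because the limit of > 50000 nM in this assay, at which 3 of the 3 values shown sit, holds all three.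

The steps between the measured compounds are a step that the two limits leave unreadable from compound 1 to compound 2, a step that the two limits leave unreadable from compound 1 to compound 3 and a step that the two limits leave unreadable from compound 2 to compound 3, none of them readable in size.

Compound 4 `N#CC1=C(N)Oc2c(N)cc3nc4ccccc4nc3c2C12C(=O)N(Cc1cnnn1-c1ccc(Cl)cc1Cl)c1ccccc12` is not yet measured. It differs from compound 3 by 2,4-dichlorophenyl in place of 2-methoxyphenyl on an aromatic nitrogen. Among the measured compounds shown here, the steps that bear on this change, all among phenyl substituents on the same aromatic nitrogen, give no readable size, so no direction in this assay can be expected beyond the scatter. The step from compound 3 to compound 4 is estimated as a step that the limit leaves unreadable from compound 3 to compound 4. In this assay compound 4 is expected to give about 60000 nM, within a range from 20000 nM to 200000 nM, most likely again as a limit.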

Compound 4, half-maximal inhibitory concentration: > 50000 nM
Compound 4 was reported as a limit (the forecaster's own chance of this, stated with the estimate: 85%); the middle value does not contradict the limit.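

No step from compound 1, compound 2 or compound 3 to compound 4 can be read in this assay, because all four compounds share one limit and none gives a number: the limit of > 50000 nM in this assay, at which 4 of the 4 values shown sit.

The compounds shown leave open how strong any of the four is in this assay, and whether the phenyl substituents compared here differ at all.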